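The compounds below may be only part of what the source reports. "The series", "measured", "known", "first", "only" and "open" are said of these compounds alone.

Compound 2, `CC1=C(C(=O)OCc2ccccc2)C(c2ccc(Cl)cc2Cl)NC(=O)N1CCCC(=O)OCc1ccccc1F`, carries a 2-fluorobenzyl ester on its chain. In an ADME assay on MCF7 cells (Homo sapiens) for cytotoxicity, read by CellTiter-Glo, with a stated time of 24 h (on this read-out higher numbers stand for weaker inhibition of growth and lower numbers for stronger inhibition of growth), compound 2 gives > 100000 nM, which is a limit of the assay and not a number. Compound 1, `CC1=C(C(=O)OCc2ccccc2)C(c2ccc(Cl)cc2Cl)NC(=O)N1CCCC(=O)OCc1ccccc1`, differs from it by hydrogen in place of fluoro on an aromatic carbon; in this assay compound 1 gives > 100000 nM, again a limit. The step that the two limits leave unreadable from compound 1 to compound 2 is therefore unreadable, and the limit of > 100000 nM in this assay, at which 2 of the 2 values shown sit, is all the measured material shows. Compound 3, `CC1=C(C(=O)OCc2ccccc2)C(c2ccc(Cl)cc2Cl)NC(=O)N1CCCC(=O)OCC1CC1`, differs from compound 2 by cyclopropyl in place of 2-fluorophenyl on a saturated chain carbon bound to an oxygen next to a carbonyl group. For the measured compounds named here, no measured step bears on this change, since the one known step cannot be read in either direction. On that basis compound 3 is expected to remain at the limit, with an estimate of 150000 nM in a range from 50000 nM to 500000 nM. The step this expectation means, a step that the limit leaves unreadable from compound 2 to compound 3, is estimated as none beyond the scatter.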

Compound 3, concentration for 50% growth inhibition: > 100000 nM
Compound 3: only a limit was reported; the forecaster's own chance of this, stated with the estimate: 85%; the middle value does not contradict the limit.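

Compound 3 also sits at a limit of the assay, so no step can be read between it and compound 1 or compound 2: the limit of > 100000 nM in this assay, at which 3 of the 3 values shown sit. The compounds shown leave open how far any of them inhibits growth in this assay, and whether any change on the shared core alters it.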